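Replacing an Octylamino Carbamate with a Dipentylamino Carbamate

The compounds below may be only part of what the source reports. "The series", "measured", "known", "first", "only" and "open" are said of these compounds alone.

Compound 3 `CCCCCCCCNC(=O)OCC1CN(C(=O)c2cc(OC)c(OC)c(OC)c2)CCN1C(=O)c1cc(OC)c(OC)c(OC)c1` is one of three carbamate or ester analogues sharing a core built around compound 1 `CCCCCCCC(=O)OCC1CN(C(=O)c2cc(OC)c(OC)c(OC)c2)CCN1C(=O)c1cc(OC)c(OC)c(OC)c1` and compound 2 `COc1cc(C(=O)N2CCN(C(=O)c3cc(OC)c(OC)c(OC)c3)C(COC(=O)NC(C)(C)C)C2)cc(OC)c1OC`. In a functional assay (Oryctolagus cuniculus) for inhibition of platelet-activating factor receptor (Cavia porcellus) (on this read-out higher numbers stand for weaker inhibition and lower numbers for stronger inhibition), compound 3 gives 370 nM, the highest of the three numbers; compound 1 gives 310 nM and compound 2 gives 130 nM. The step of a 1.2-fold higher number from compound 1 to compound 3 (0.08 log units; within the scatter) lies within the scatter, whereas a 2.8-fold higher number from compound 2 to compound 3 (0.45 log units; beyond the scatter) and a 2.4-fold lower number from compound 1 to compound 2 (0.38 log units; beyond the scatter) are modest but real.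

Compound 4 `CCCCCN(CCCCC)C(=O)OCC1CN(C(=O)c2cc(OC)c(OC)c(OC)c2)CCN1C(=O)c1cc(OC)c(OC)c(OC)c1` differs from compound 3 by dipentylamino in place of octylamino on a carbonyl carbon. The measured steps that bear on this are a 2.8-fold higher number from compound 2 to compound 3 (0.45 log units; beyond the scatter), where a longer chain on the amide-type nitrogen gave a somewhat higher number, and a 1.2-fold higher number from compound 1 to compound 3 (0.08 log units; within the scatter), which showed no change beyond the scatter. Going by the values given here, no measured pair removes the hydrogen-bond donor, so the effect of that part of the change is unknown. On this basis compound 4 is expected to stay close to compound 3, with a step of a 1.1-fold higher number from compound 3 to compound 4 (0.03 log units; within the scatter) that is expected to fall within the scatter. The estimate for compound 4 is therefore 400 nM, with a range from 150 nM to 1100 nM.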

Compound 4, half-maximal inhibitory concentration: 11400 nM
Estimate against measurement, compound 4: 29-fold (1.45 log units) below, outside the stated range (above it).
By their numbers in this assay, from the lowest: compound 2; then compounds 1 and 3 (each within the scatter of the next); then compound 4.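

Going by these compounds alone, with dipentylamino on the carbonyl carbon, this position stops tolerating the change: in this assay there is a 31-fold higher number from compound 3 to compound 4 (1.49 log units; beyond the scatter), together with an 88-fold higher number from compound 2 to compound 4 (1.94 log units; beyond the scatter) and a 37-fold higher number from compound 1 to compound 4 (1.57 log units; beyond the scatter), steps far larger than any among the earlier compounds. Loss of the amide hydrogen does not by itself go with such a rise, since compound 1, with heptyl on the same carbonyl carbon, also lacks that hydrogen and stays within the scatter of compound 3. No measurement at hand explains the size of this step.

The compounds shown leave open whether two chains on the nitrogen are enough for the rise or whether their length matters, as dimethylamino or diethylamino would show. They also leave open whether methyl(octyl)amino, with one long chain kept, would stay close to compound 3.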